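This account rests on a few compounds, and the source may have more. Where it says the series, first, only, none or still open, it means among the compounds named here.

Compound 1 `N#Cc1cnc(NCc2cnccc2C(F)(F)F)cc1N[C@H]1C[C@H](O)C1`: in an assay on isolated protein for inhibition of protein kinase C delta type (Homo sapiens), read by TR-FRET, with a stated time of 2 h (a lower number here means a stronger inhibitor, a higher number a weaker inhibitor), compound 1 gives > 10000 nM, a limit of the assay.
Compound 2 `N#Cc1cnc(NCc2cnccc2C(F)(F)F)cc1NCCC1CCOCC1`: in this assay compound 2 gives > 10000 nM, again a limit.
Compound 3 `CC1(C)C[C@@H](Nc2cc(NCc3cnccc3C(F)(F)F)ncc2C#N)CC[C@H]1O`: in this assay compound 3 gives 2400 nM.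

For the measured compounds named here, compound 3 thus holds the only readable number; the other two values sit at the limit of > 10000 nM in this assay, at which 2 of the 3 values shown sit. Compound 4 `CC1(C)[C@@H](C(N)=O)C[C@H]1Nc1cc(NCc2cnccc2C(F)(F)F)ncc1C#N` differs from compound 3 by 3-carbamoyl-2,2-dimethylcyclobutyl in place of 4-hydroxy-3,3-dimethylcyclohexyl on a nitrogen on an aromatic ring. Going by the values given here, the steps that bear on this are an at least 4.1-fold lower number from compound 1 to compound 3 (0.61 log units; beyond the scatter) and an at least 4.1-fold lower number from compound 2 to compound 3 (0.61 log units; beyond the scatter), each at least modest, and both point to the 4-hydroxy-3,3-dimethylcyclohexyl group as the only one giving a number. Compound 4 returns to a four-membered ring, as in compound 1, now carrying carbamoyl and dimethyl groups, so a step back toward the limit is expected, a 2.5-fold higher number from compound 3 to compound 4 (0.40 log units; beyond the scatter). Compound 4 is therefore estimated at 6000 nM, between 1500 nM and 20000 nM.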

Compound 4, half-maximal inhibitory concentration: 160 nM
Estimate against measurement, compound 4: 38-fold (1.57 log units) above; the measured number lies below the stated range.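

On a nitrogen on an aromatic ring, 3-carbamoyl-2,2-dimethylcyclobutyl gives a 15-fold lower number from compound 3 to compound 4 (1.18 log units; beyond the scatter) in this assay, so a six-membered ring is not needed here for a readable number, and a four-membered ring need not sit at the limit. Against 3-hydroxycyclobutyl the same group gives an at least 62-fold lower number from compound 1 to compound 4 (1.79 log units; beyond the scatter), and against 2-(oxan-4-yl)ethyl it gives an at least 62-fold lower number from compound 2 to compound 4 (1.79 log units; beyond the scatter). These two steps are bounds and not sizes: the limit of > 10000 nM in this assay, at which 2 of the 4 values shown sit.

The compounds shown do not separate the carbamoyl group from the two methyl groups. They also leave open whether a carboxylic acid or an amine in place of carbamoyl on the same cyclobutyl would keep the number.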